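The source may hold more compounds than are shown below. What is called first, only, known or untested is meant among the compounds shown, and "the series" means these compounds.

In a functional assay on L1210 cells (Mus musculus) for antiproliferative activity, read by CCK-8 assay (a lower number here means a stronger inhibitor, a higher number a weaker inhibitor), compound 3 `Oc1ccccc1/C=N/c1nnc(SCc2c[se]c(-c3ccccc3)n2)s1` gives 38700 nM, and it stands at the low edge of three numbers that all sit within the scatter of one another. Compound 1 `Fc1ccc(/C=N/c2nnc(SCc3c[se]c(-c4ccccc4)n3)s2)cc1` gives 56900 nM in this assay, and compound 2 `Brc1ccc(/C=N/c2nnc(SCc3c[se]c(-c4ccccc4)n3)s2)cc1` gives 46500 nM. The steps of a 1.2-fold lower number from compound 1 to compound 2 (0.09 log units; within the scatter), a 1.5-fold lower number from compound 1 to compound 3 (0.17 log units; within the scatter) and a 1.2-fold lower number from compound 2 to compound 3 (0.08 log units; within the scatter) each changed only the aryl group on the carbon with a double bond to nitrogen, and none of them left the scatter. Compound 4 `CN(C)c1ccc(/C=N/c2nnc(SCc3c[se]c(-c4ccccc4)n3)s2)cc1` differs from compound 3 at the same place: 4-(dimethylamino)phenyl in place of 2-hydroxyphenyl on a carbon with a double bond to nitrogen. Three swaps at this position produced no change beyond the scatter, so the step of a 1.1-fold higher number from compound 3 to compound 4 (0.04 log units; within the scatter) is expected to be small as well. Compound 4 is estimated at 42000 nM, with a range from 15000 nM to 110000 nM.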

Compound 4, half-maximal inhibitory concentration: > 100000 nM
Compound 4: a limit, no number; the forecaster's own chance of this, stated with the estimate: 10%; middle value at least 2.3-fold (0.37 log units) away from the limit.
By their numbers in this assay, from the lowest: compounds 3, 2 and 1 (each within the scatter of the next). At a limit, above all of these: compound 4.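

In this assay compound 4 gives > 100000 nM, which is a limit of the assay and not a number. For the compounds shown here, the aryl group on the carbon with a double bond to nitrogen had so far produced no change beyond the scatter, but 4-(dimethylamino)phenyl does, with an at least 2.5-fold higher number from compound 3 to compound 4 (0.41 log units; beyond the scatter) and an at least 2.1-fold higher number from compound 2 to compound 4 (0.33 log units; beyond the scatter). The third step, an at least 1.7-fold higher number from compound 1 to compound 4 (0.24 log units; that floor lies within the scatter), does not by itself establish such a change.

As far as these compounds go, how far compound 4 lies past its limit stays open. So does whether a primary amine or a carboxylic acid on this aryl group would read like compound 4 or like compound 3.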